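Imine series, P388 cytotoxicity: aryl swap toward 2-chlorophenyl

This account rests on a few compounds, and the source may have more. Where it says the series, first, only, none or still open, it means among the compounds named here.

Among the measured compounds shown here, compound 2 `Cc1c(/N=C/c2cccc(O)c2)c(=O)n(-c2ccccc2)n1C` gives 437000000 nM in a functional assay on P388 cells (Mus musculus) for cytotoxicity, read by MTT assay, with a stated time of 72 h (a lower number here means a stronger inhibitor, a higher number a weaker inhibitor), the highest of the two numbers measured so far; the nearest is compound 1 `COc1ccc(/C=N/c2c(C)n(C)n(-c3ccccc3)c2=O)cc1`, which gives 186000000 nM. For the measured compounds named here, the only measured step on this carbon, a 2.3-fold higher number from compound 1 to compound 2 (0.37 log units; beyond the scatter), is modest. Compound 3 `Cc1c(/N=C/c2ccccc2Cl)c(=O)n(-c2ccccc2)n1C` is not yet measured; it differs from compound 2 by 2-chlorophenyl in place of 3-hydroxyphenyl on a carbon with a double bond to nitrogen. Going by the values given here, no measured step involves a 2-chlorophenyl, so the bearing of the data is indirect: one aryl exchange at this position moved the number only modestly, so a similarly modest move is expected here, and since compound 1 likewise carries no hydrogen-bond donor on its aryl and gives 186000000 nM, the lean is toward a lower number. For compound 3 the estimate is 250000000 nM, range 100000000 nM to 600000000 nM, an expected step of a 1.7-fold lower number from compound 2 to compound 3 (0.24 log units; within the scatter) that stays within the scatter.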

Compound 3, half-maximal inhibitory concentration: 324000000 nM
For compound 3 the middle estimate is 1.3-fold (0.11 log units) below the measured one; measured number inside the range.
By their numbers in this assay, from the lowest: compounds 1, 3 and 2 (each within the scatter of the next, the first and the last beyond it).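

In this assay, 2-chlorophenyl in place of 3-hydroxyphenyl on a carbon with a double bond to nitrogen gives a 1.3-fold lower number from compound 2 to compound 3 (0.13 log units; within the scatter), and 2-chlorophenyl in place of 4-methoxyphenyl gives a 1.7-fold higher number from compound 1 to compound 3 (0.24 log units; within the scatter). Compound 3 therefore cannot be separated from either compound 1 or compound 2, even though those two lie beyond the scatter of each other. Giving up the hydrogen-bond donor and acceptor counted for 3-hydroxyphenyl produces no step beyond the scatter here, and nothing available explains the size of these steps.

The compounds shown leave open whether an aryl carrying an amine or a carboxylic acid, or a longer chain in place of the aryl, would move the number beyond the scatter. Also open, from the compounds shown here alone, is how the number responds to changes on the shared core, which stays the same in all three compounds.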